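The compounds below may be only part of what the source reports. "The series", "measured", "known", "first", "only" and "open" are said of these compounds alone.

Of the compounds shown here, two built on one shared core have been tested in a functional assay on the whole organism (strain Swiss) for inhibition, with Mus musculus as the target, in the formalin test, with stated times of 40 min and 30 min, at a dose of 100 umol/kg by the oral route; on this read-out lower numbers stand for less inhibition and higher numbers for more inhibition at the one dose given (going by the name of the read-out). Compound 1, `O=C(N/N=C/c1ccc(-c2ccccc2)cc1)c1cnccn1`, gives 46.9%. Compound 2, `CC(C)c1ccc(/C=N/NC(=O)c2cnccn2)cc1`, gives 66.5%. For the measured compounds named here, of these two numbers, compound 2 stands highest; its only neighbour is compound 1, and the step of a number 19.6 percentage points higher from compound 1 to compound 2 (beyond the scatter) lies beyond the scatter.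

Compound 3, `O=C(N/N=C/c1ccc(F)cc1)c1cnccn1`, has not yet been measured in this assay. It differs from compound 2 in one place: fluoro in place of isopropyl on an aromatic carbon. The group sits on an aromatic carbon of a six-membered aromatic ring of carbon only, para to a large group.

Going by the values given here, only one measured step bears on this change, and only loosely: a number 19.6 percentage points higher from compound 1 to compound 2 (beyond the scatter), which exchanged a group at the same place. Among the compounds with values here, no measured pair shows fluoro there, so the size of the coming step cannot be read from a matching example. With a group of one heavy atom in place of isopropyl, a modest fall is expected, a number 13.5 percentage points lower from compound 2 to compound 3 (beyond the scatter), though a result within the scatter cannot be ruled out. Compound 3 is therefore estimated at 53%, with a range from 36% to 70%.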

Compound 3, a percentage reported as inhibition, in the whole organism at one dose (the size of the read-out at that dose, not a potency): 72.3%
For compound 3 the middle estimate is 19.3 percentage points below the measured one, outside the stated range (above it).
By their numbers in this assay, from the lowest: compound 1; then compounds 2 and 3 (each within the scatter of the next).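

Placing fluoro where isopropyl stood on the aromatic carbon leaves the response in this assay within the scatter (a number 5.8 percentage points higher from compound 2 to compound 3 (within the scatter)), even though the group shrinks from 3 heavy atoms to 1 heavy atom, so on this read-out compound 2 and compound 3 cannot be told apart. Fluoro also separates from phenyl at this place (a number 25.4 percentage points higher from compound 1 to compound 3 (beyond the scatter)), which means that compound 1 now stands apart from two compounds rather than one, and that the earlier gap between phenyl and isopropyl was not special to isopropyl. Nothing available explains why these three groups give these results.

As far as these compounds go, it remains open whether an amine, a carboxylic acid, a methoxy group or a longer chain at this place would stay level with compound 2 and compound 3 or fall toward compound 1. These compounds also leave the rest of the shared core unchanged, and with only one dose, the read-out gives the size of the response at that dose and not a potency.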